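The source may report more compounds than this note shows. Statements on the series, on what has been measured and on what is new or still open speak of the compounds shown alone.

Working notes on the series. Compound 3 `O=C(c1ccccc1)N1CCC(NCC[S+]([O-])C(c2ccc(F)cc2)c2ccc(F)cc2)CC1` gives 79.1 nM in an assay on membranes from striatum (strain Sprague-Dawley) for displacement of a labelled ligand from sodium-dependent dopamine transporter (Rattus norvegicus), read by scintillation counting, with a stated time of 120 min (a lower number here means a stronger inhibitor, a higher number a weaker inhibitor), the highest of the three numbers recorded. The nearest is compound 1 `Fc1ccc(C(SCCNC2CCN(Cc3ccccc3)CC2)c2ccc(F)cc2)cc1`, at 32.9 nM; the furthest is compound 2 `O=C(c1ccccc1)N1CCC(NCCSC(c2ccc(F)cc2)c2ccc(F)cc2)CC1`, at 4.51 nM.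

The next compound, compound 4 `CC(C)(C)CN1CCC(NCC[S+]([O-])C(c2ccc(F)cc2)c2ccc(F)cc2)CC1`, differs from compound 3 by neopentyl in place of benzoyl on an amine nitrogen in a ring. Among the compounds with values here, the one measured step at this position is a 7.3-fold lower number from compound 1 to compound 2 (0.86 log units; beyond the scatter), in which the benzoyl entered and the number fell. Within the data shown here, compound 4 removes the benzoyl again, so a step back upward is the natural reading, though the group that enters is neopentyl, not benzyl, and no neopentyl analogue has been measured, so the size carries wide uncertainty.

Compound 4 is therefore expected to show a higher number than compound 3, with the step of a 4.4-fold higher number from compound 3 to compound 4 (0.65 log units; beyond the scatter) as the estimate. The estimate for compound 4 in this assay is 350 nM, within a range from 80 nM to 1500 nM.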

Compound 4, inhibition constant: 431 nM
Compound 4: middle estimate off by 1.2-fold (0.09 log units), on the low side, within the range that was stated.
By their numbers in this assay, from the lowest: compound 2; then compound 1; then compound 3; then compound 4.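

In this assay, the benzoyl group again goes with the lower number, now on the sulfoxide: removing it gives a 5.4-fold higher number from compound 3 to compound 4 (0.74 log units; beyond the scatter). Together with a 7.3-fold lower number from compound 1 to compound 2 (0.86 log units; beyond the scatter), this gives two single-place steps at the ring nitrogen, both beyond the scatter and both favouring benzoyl, one against benzyl on the thioether and one against neopentyl on the sulfoxide; within these four compounds, the preference for benzoyl therefore holds across both partner groups and both sulfur forms. No measurement at hand explains the step.

On these data alone, it remains open whether the carbonyl or the aromatic ring of the benzoyl group goes with the lower number, which a pivaloyl or cyclohexanecarbonyl group at the same nitrogen would help separate. A benzyl group on the sulfoxide would also allow neopentyl and benzyl to be compared directly.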